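Iodo for chloro: a step into unmeasured territory

The compounds below may be only part of what the source reports. "The series", "measured", "known", "first", "only" and "open" are said of these compounds alone.

Compound 1 `C/C(=N\NC(=O)c1ccncc1)C(=O)Nc1ccc(F)cc1` was tested in an ADME assay on HepG2 cells (Homo sapiens) for cytotoxicity, read by MTT assay; on this read-out lower numbers stand for stronger inhibition and higher numbers for weaker inhibition. In this assay compound 1 gives only the limit > 50000 nM, which is not a number. Compound 2 `C/C(=N\NC(=O)c1ccncc1)C(=O)Nc1ccc(Cl)cc1` in this assay likewise reaches only the limit > 50000 nM. The step that the two limits leave unreadable from compound 1 to compound 2 therefore cannot be sized, and compound 2 stands at the limit like its neighbour. Compound 3 `C/C(=N\NC(=O)c1ccncc1)C(=O)Nc1ccc(I)cc1` differs from compound 2 by iodo in place of chloro on an aromatic carbon. Within the data shown here, the only bearing evidence is the limit of > 50000 nM in this assay, at which 2 of the 2 values shown sit, so no shift beyond the scatter is expected in either direction. Compound 3 is expected to give 80000 nM, between 30000 nM and 200000 nM. The step that the limit leaves unreadable from compound 2 to compound 3 is thus expected to be flat.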

Compound 3, half-maximal inhibitory concentration: > 50000 nM
Compound 3: only a limit was reported (the forecaster's own chance of this, stated with the estimate: 85%); the middle value is on the limit's open side.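

Among these compounds, compound 1, compound 2 and compound 3 all give only a limit in this assay, so no step among them can be read. The compounds shown leave open whether fluoro, chloro and iodo differ at all here.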